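Sulfonyl aryl swap on the shared core: compound 1 to compound 4

The compounds below may be only part of what the source reports. "The series", "measured", "known", "first", "only" and "open" are said of these compounds alone.

Three compounds of the series have numbers in an assay on isolated protein for displacement of a labelled ligand from metabotropic glutamate receptor 5 (Homo sapiens), with a stated time of 60 min, tested at 1 uM; on this read-out lower numbers stand for less inhibition and higher numbers for more inhibition at the one concentration tested (going by the name of the read-out). Compound 1 `COc1ccc(S(=O)(=O)c2cnc3cc(F)ccc3c2N2CCC(C)CC2)cc1OC` gives 83% in this assay. Compound 2 `CC1CCN(c2c(S(=O)(=O)c3ccc(Cl)cc3)cnc3c(F)cccc23)CC1` gives 85% in this assay, and compound 3 `CC1CCN(c2c(S(=O)(=O)c3ccc(Cl)c(Cl)c3)cnc3ccc(F)cc23)CC1` gives 91% in this assay. Compound 1 holds the lowest of the three numbers, yet its gaps to compound 2 and to compound 3 both lie within the usual scatter, so no ranking among the three follows from these values. Within the data shown here, no single-point step between measured compounds is available in this assay.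

Compound 4 `CC1CCN(c2c(S(=O)(=O)c3cc(Cl)cc(Cl)c3)cnc3cc(F)ccc23)CC1` is not yet measured. It differs from compound 1 in one place: 3,5-dichlorophenyl in place of 3,4-dimethoxyphenyl on a sulfonyl sulfur. The three measured values sit close together despite different aryl groups on the sulfonyl sulfur, which gives no ground to expect a step beyond the scatter in either direction. The expected step from compound 1 to compound 4 is a number 3 percentage points higher from compound 1 to compound 4 (within the scatter), effectively none beyond the scatter. Compound 4 is estimated at 86%, with a range from 70% to 96%.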

Compound 4, a percentage reported as inhibition, at one concentration (the size of the read-out at that concentration, not a potency): 87%
Beside the measured number, compound 4's estimate is 1 percentage points below it; the measured number falls inside the stated range.
By their numbers in this assay, from the lowest: compounds 1, 2, 4 and 3 (each within the scatter of the next).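

In this assay, the series now has its first comparison of compounds that differ in one place: 3,5-dichlorophenyl in place of 3,4-dimethoxyphenyl on a sulfonyl sulfur gives a number 4 percentage points higher from compound 1 to compound 4 (within the scatter). At this position, the count of hydrogen-bond acceptors in the group falls from 2 to 0 and the two methoxy-bearing ring is exchanged for a dichlorinated one, yet the step stays within the scatter. No measurement is at hand that explains the size of this step.

Going by these compounds, whether a carboxylic acid or an amine on the sulfonyl sulfur would produce a step beyond the scatter remains open. On these data alone, since the read-out reports inhibition at one concentration, any potency difference between these compounds also remains open.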